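A few compounds are considered here, and "the series" means these few. Any claim that something is new, unique, unknown or untested is made for them only; others in the source may bear on it.

Series notes. Among the compounds with values here, in a functional assay for activation of Alpha-1A adrenergic receptor (Homo sapiens), read by calcium flux (on this read-out lower numbers stand for an effect already at smaller amounts and higher numbers for an effect only at larger amounts of compound), compound 3 `Cc1cc(-c2ccccc2NCC2=NCCN2)on1` gives 38.9 nM, the second highest of the three numbers so far; compound 1 `c1ccc(-c2cnco2)c(NCC2=NCCN2)c1` gives 17.4 nM and compound 2 `Cc1ncc(-c2ccccc2NCC2=NCCN2)o1` gives 110 nM. Compound 4 `Cc1ccsc1-c1ccccc1NCC1=NCCN1` differs from compound 3 by 3-methylthiophen-2-yl in place of 3-methyl-1,2-oxazol-5-yl on an aromatic carbon, on an aromatic carbon of a six-membered aromatic ring of carbon only. Every change of the five-membered ring measured so far moved this assay only modestly: a 2.2-fold higher number from compound 1 to compound 3 (0.35 log units; beyond the scatter), a 2.8-fold lower number from compound 2 to compound 3 (0.45 log units; beyond the scatter), and a 6.3-fold higher number from compound 1 to compound 2 (0.80 log units; beyond the scatter). A step of similar modest size, in either direction, is therefore expected here; nothing measured points to one side. Compound 4 is estimated at 50 nM (range 12 nM to 200 nM), meaning an expected 1.3-fold higher number from compound 3 to compound 4 (0.11 log units; within the scatter).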

Compound 4, half-maximal effective concentration: 0.851 nM
Estimate against measurement, compound 4: 59-fold (1.77 log units) above, and the stated range ends above it.
By their numbers in this assay, from the lowest: compound 4; then compound 1; then compound 3; then compound 2.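

In this assay, the five-membered ring at this place, on an aromatic carbon of a six-membered aromatic ring of carbon only, proves able to produce large steps and not just modest ones: 3-methylthiophen-2-yl gives a 46-fold lower number from compound 3 to compound 4 (1.66 log units; beyond the scatter), a 130-fold lower number from compound 2 to compound 4 (2.11 log units; beyond the scatter) and a 20-fold lower number from compound 1 to compound 4 (1.31 log units; beyond the scatter). Each of these exceeds every step among compounds 1, 2 and 3. Nothing at hand accounts for the size of this change.

Still open, as far as these compounds go, is whether the thiophene ring or its methyl carries the effect. A thiophen-2-yl without the methyl would separate the two, and a plain phenyl here would test whether a ring hetero atom is needed at all.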